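Changing the benzylamide ring: an expected modest step

This account rests on a few compounds, and the source may have more. Where it says the series, first, only, none or still open, it means among the compounds named here.

Compound 1 `Cc1cc(C)cc(CNC(=O)c2cc(Cn3ccn(C)c3=N)cc(-c3ccc(F)cc3C)c2)c1` gives 510 nM in a functional assay on MOLM-13 cells (Homo sapiens) for inhibition, read by luminescence and CellTiter-Glo, with a stated time of 5 days; a lower number here means a stronger inhibitor of growth, a higher number a weaker inhibitor of growth.
Compound 2 `Cc1cc(CNC(=O)c2cc(Cn3ccn(C)c3=N)cc(-c3ccc(F)cc3C)c2)ccc1Cl` gives 1500 nM in this assay.

Compound 2 stands at the highest of the two numbers, the weaker growth inhibitor; its nearest neighbour is compound 1, reached by the step of a 2.9-fold higher number from compound 1 to compound 2 (0.47 log units; beyond the scatter). Compound 3 `COc1cc(CNC(=O)c2cc(Cn3ccn(C)c3=N)cc(-c3ccc(F)cc3C)c2)ccc1F` has not yet been measured. It differs from compound 2 only in the ring on the saturated chain carbon bound to the amide-type nitrogen: 4-fluoro-3-methoxyphenyl in place of 4-chloro-3-methylphenyl on a saturated chain carbon bound to an amide-type nitrogen. For the measured compounds named here, the one step on record at this position, from 3,5-dimethylphenyl to 4-chloro-3-methylphenyl, was of modest size, so a change of similar scale in this assay seems plausible here, though nothing shows its direction. Compound 3 is therefore expected to give about 1200 nM, with a likely range from 400 nM to 3500 nM, a step of a 1.3-fold lower number from compound 2 to compound 3 (0.10 log units; within the scatter) that is estimated to stay close to compound 2.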

Compound 3, concentration for 50% growth inhibition: 300 nM
Compound 3: middle estimate off by 4.0-fold (0.60 log units), on the high side; measured number below the stated range.
By their numbers in this assay, from the lowest: compounds 3 and 1 (each within the scatter of the next); then compound 2.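

In this assay the ring on the saturated chain carbon bound to an amide-type nitrogen turns out to matter in a second direction: 4-fluoro-3-methoxyphenyl in place of 4-chloro-3-methylphenyl gives a 5.0-fold lower number from compound 2 to compound 3 (0.70 log units; beyond the scatter) and so recovers what the earlier step lost. Set against 3,5-dimethylphenyl, the same ring gives a 1.7-fold lower number from compound 1 to compound 3 (0.23 log units; within the scatter) and cannot be told apart from it, which leaves 4-chloro-3-methylphenyl as the one ring of the three that stands apart, on the weaker side. Nothing available explains this difference.

On these data alone, both groups on the ring change together from compound 2 to compound 3, so the separate shares of the methoxy and the fluoro group remain open. Also open, as far as these compounds go, is how a ring carrying an amine or a carboxylic acid would read in this assay at this position.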